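The source may report more compounds than this note shows. Statements on the series, on what has been measured and on what is new or still open speak of the compounds shown alone.

Measured so far:
- compound 1, `COc1ccc(Cl)cc1-c1cc(Nc2ccc(Cl)cc2)nc(N)n1`, gives 54 nM in an assay on Sf9 cells for inhibition of 1-acyl-sn-glycerol-3-phosphate acyltransferase beta (Homo sapiens); on this read-out higher numbers stand for weaker inhibition and lower numbers for stronger inhibition
- compound 2, `CCOc1ccc(Br)cc1-c1cc(Nc2ccc(B(O)O)cc2)nc(N)n1`, gives 91 nM in this assay

Compound 2 has the highest of the two numbers seen so far, but its nearest neighbour, compound 1, sits within the usual scatter of it, so the two cannot be told apart on these data. Compound 3, `CCOc1ccc(Br)cc1-c1cc(Nc2ccc(C#N)cc2)nc(N)n1`, has not yet been measured. It differs from compound 2 in one place: a group of 2 heavy atoms (1 carbon, 1 nitrogen; no ring) in place of a group of 3 heavy atoms (1 boron, 2 oxygen; no ring), on an aromatic carbon. The group that leaves carries two hydrogen-bond donors and two acceptors; the cyano that enters carries no donor and one acceptor.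

Among the measured compounds shown here, no pair of measured compounds differs in this single place, so there is no measured step to lean on; only the two values above and the structural change itself inform the expectation. On that basis, the step expected in this assay is small, a 1.3-fold lower number from compound 2 to compound 3 (0.11 log units; within the scatter), which is not beyond the scatter in either direction. Compound 3 is therefore expected to come out near 70 nM, with a likely range from 25 nM to 200 nM.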

Compound 3, half-maximal inhibitory concentration: 17 nM
Beside the measured number, compound 3's estimate is 4.1-fold (0.61 log units) above it, and the stated range ends above it.
By their numbers in this assay, from the lowest: compound 3; then compounds 1 and 2 (each within the scatter of the next).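

Among the compounds shown here, this is the first step measured at this position, the aromatic carbon para to a large group, and it shows that the position responds to what sits there: in this assay, putting cyano in place of the group of boron and two oxygens gives a 5.4-fold lower number from compound 2 to compound 3 (0.73 log units; beyond the scatter). A lower number here means stronger inhibition, so the two hydrogen-bond donors of the leaving group are not needed for a low number, as compound 3, with no donor on the entering cyano, gives 17 nM. Nothing available on these compounds accounts for the size of this step.

For the compounds shown here, with only one step at this position, it remains open whether cyano is unusual or the group of boron and two oxygens is simply a poor fit for a low number, and an amine, a carboxylic acid or a methoxy group in the same place would help separate those two readings. On these data alone, it is also open whether the step carries over to the core of compound 1, which differs from compound 3 in more than one place and so cannot be compared with it directly.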